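The compounds below may be only part of what the source reports. "The series", "measured", "known", "first", "only" and "open" are said of these compounds alone.

Compound 2 `CC(C)(C)c1ccc(NC(=O)c2ccc(-c3ncccc3C#N)cc2)cc1` carries a cyano group on the six-membered aromatic ring with one nitrogen, and in a functional assay for antagonist activity at transient receptor potential cation channel subfamily V member 1 (Rattus norvegicus) (on this read-out higher numbers stand for weaker inhibition and lower numbers for stronger inhibition), compound 2 gives 13 nM, the lowest of the three numbers measured. Compound 3 `CC(C)(C)c1ccc(NC(=O)c2ccc(-c3ncccc3-c3ncc[nH]3)cc2)cc1` has a 1H-imidazol-2-yl at that place instead, and in this assay compound 3 gives 694 nM; the step of a 53-fold higher number from compound 2 to compound 3 (1.73 log units; beyond the scatter) is large. Going by the values given here, compound 1 `N#Cc1ccc(NC(=O)c2ccc(-c3ncccc3C(F)(F)F)cc2)cc1` differs from compound 2 in two places, so no single step can be drawn from it, and in this assay compound 1 gives 1300 nM. Compound 4 `CC(C)(C)c1ccc(NC(=O)c2ccc(-c3ncccc3-c3nnco3)cc2)cc1` has not yet been measured; it differs from compound 2 as follows: 1,3,4-oxadiazol-2-yl in place of cyano on an aromatic carbon. Among the compounds with values here, the one measured step that bears on this change is the replacement of the cyano group by a five-membered aromatic ring in compound 3, where the number rose sharply. Compound 4 is therefore expected to give a clearly higher number than compound 2, with a step of about a 31-fold higher number from compound 2 to compound 4 (1.49 log units; beyond the scatter). In this assay compound 4 is estimated at 400 nM, with a range from 100 nM to 1600 nM.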

Compound 4, half-maximal inhibitory concentration: 59 nM
For compound 4 the middle estimate is 6.8-fold (0.83 log units) above the measured one; the measured number lies below the stated range.
By their numbers in this assay, from the lowest: compound 2; then compound 4; then compounds 3 and 1 (each within the scatter of the next).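

In this assay a five-membered aromatic ring at this place, ortho to a large group, does not have to bring the sharp rise seen with compound 3: the 1,3,4-oxadiazol-2-yl gives only a 4.5-fold higher number from compound 2 to compound 4 (0.66 log units; beyond the scatter) and the nitrile of compound 2 still holds the lowest number. The identity of the ring therefore matters at this place, with a 12-fold lower number from compound 3 to compound 4 (1.07 log units; beyond the scatter) on exchanging one five-membered ring for the other. No evidence is available that accounts for the gap between these two rings.

The compounds shown leave open how far the outcome depends on the arrangement of atoms within the ring, which a 1,2,4-oxadiazol-5-yl or a 1,3-oxazol-2-yl at this place would address. They also leave open how a non-ring group such as a primary carboxamide or a methoxy would compare with the nitrile.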